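A few compounds are considered here, and "the series" means these few. Any claim that something is new, unique, unknown or untested is made for them only; others in the source may bear on it.

Compound 1 `CC(=O)N1CCN(c2ccc(Nc3ncc(C#N)c(-c4c[nH]c5ccccc45)n3)cc2)CC1` is tested in a functional assay on MV4-11 cells (Homo sapiens) for antiproliferative activity, read by resazurin assay, with a stated time of 72 h (on this read-out lower numbers stand for stronger inhibition of growth and higher numbers for weaker inhibition of growth), where compound 1 gives 4 nM. Compound 2 `CC(=O)N1CCN(c2ccc(Nc3ncc(C#N)c(-c4cn(C)c5ccccc45)n3)cc2)CC1` carries methyl in place of hydrogen on an aromatic nitrogen, and in this assay compound 2 gives 30 nM. That change brought a 7.5-fold higher number from compound 1 to compound 2 (0.88 log units; beyond the scatter). Compound 3 `CC(=O)N1CCN(c2ccc(Nc3nccc(-c4c[nH]c5ncccc45)n3)cc2)CC1` is built on a different core, and the difference between the two cores is not broken down here. In this assay the value of compound 3 is a limit of the assay, < 1 nM. Compound 3 thus sits at the limit of < 1 nM in this assay, at which 1 of the 3 values shown sits. Compound 4 `CC(=O)N1CCN(c2ccc(Nc3nccc(-c4cn(C)c5ncccc45)n3)cc2)CC1` is not yet measured; it differs from compound 3 by methyl in place of hydrogen on an aromatic nitrogen, the same change that separates compound 1 from compound 2, at the same place. Because the first occurrence gave a 7.5-fold higher number from compound 1 to compound 2 (0.88 log units; beyond the scatter), a step of similar size is expected from compound 3 to compound 4, roughly an at least 3.0-fold higher number from compound 3 to compound 4 (0.47 log units; beyond the scatter). As the starting point of compound 3 is only a limit, the expected number for compound 4 is less certain at its lower end. Compound 4 is therefore estimated to give 3 nM in this assay, within a range of 0.7 nM to 15 nM.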

Compound 4, concentration for 50% growth inhibition: 74 nM
Compound 4: middle estimate off by 25-fold (1.39 log units), on the low side, and the stated range ends below it.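

In this assay, methyl in place of hydrogen on an aromatic nitrogen again gave a weaker result, with an at least 74-fold higher number from compound 3 to compound 4 (1.86 log units; beyond the scatter). The direction of the change carried over from one core to the other, but its size did not: the same change on two cores in this assay, a 7.5-fold higher number (0.88 log units; beyond the scatter) from compound 1 to compound 2 and an at least 74-fold higher number (1.86 log units; beyond the scatter) from compound 3 to compound 4, at least 9.8-fold (0.99 log units) apart, beyond the scatter of two such steps

The value of compound 3 is a limit of the assay, < 1 nM, and the two steps show neither how large the step on that core truly is nor which difference between the two cores goes with the gap.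

The compounds shown leave open whether another group on that aromatic nitrogen, such as ethyl or a longer chain ending in an amine, would follow the same course on either core. They also leave open how much of the gap goes with the nitrile, which compound 1 and compound 2 carry, as no pair shown separates it from the other difference between the cores.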